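A Pyrazole in Place of the Cyanofluorophenyl Group

The source may hold more compounds than are shown below. What is called first, only, known or untested is meant among the compounds shown, and "the series" means these compounds.

compound 1 `N#Cc1cc(-c2nc(C(c3ccc(F)cc3)c3ccc(F)cc3)sc2CC(=O)O)ccc1F`: 520 nM
compound 2 `O=C(O)Cc1sc(C(c2ccc(F)cc2)c2ccc(F)cc2)nc1-c1cc(F)cc(F)c1`: 340 nM
compound 3 `O=C(O)Cc1sc(C(c2ccc(F)cc2)c2ccc(F)cc2)nc1-c1cc(F)nc(F)c1`: 110 nM

In an in vitro functional assay on HEK285-7 cells for antagonist activity at prostaglandin D2 receptor 2 (Homo sapiens), read by BRET and beta-arrestin recruitment (on this read-out higher numbers stand for weaker inhibition and lower numbers for stronger inhibition), compound 1 stands highest of the three numbers; compound 2 is nearest, and compound 3 is furthest from it. Compound 4 `O=C(O)Cc1sc(C(c2ccc(F)cc2)c2ccc(F)cc2)nc1-c1cn[nH]c1` keeps the shared core of compound 1 and changes only the group on the aromatic carbon of the five-membered ring: 1H-pyrazol-4-yl in place of 3-cyano-4-fluorophenyl on an aromatic carbon.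

Two measured steps start from compound 1. The step of a 1.5-fold lower number from compound 1 to compound 2 (0.18 log units; within the scatter) is within the scatter, whereas the step of a 4.7-fold lower number from compound 1 to compound 3 (0.67 log units; beyond the scatter) is modest but real, and the step of a 3.1-fold lower number from compound 2 to compound 3 (0.49 log units; beyond the scatter) points the same way. None of these steps puts a five-membered ring with a hydrogen-bond donor in this place, so they bear on compound 4 only indirectly. Therefore the expected step is a 1.7-fold lower number from compound 1 to compound 4 (0.24 log units; within the scatter), with wide uncertainty. Compound 4 is estimated at 300 nM, within a range of 80 nM to 1500 nM.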

Compound 4, half-maximal inhibitory concentration: 220 nM
Compound 4: the middle estimate sits 1.4-fold (0.13 log units) above what was measured; the measured number falls inside the stated range.
By their numbers in this assay, from the lowest: compounds 3, 4, 2 and 1 (each within the scatter of the next, the first and the last beyond it).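

In this assay, the result shows that this aromatic carbon does not need a six-membered ring: with a 2.4-fold lower number from compound 1 to compound 4 (0.37 log units; beyond the scatter) as a modest step, the smaller 1H-pyrazol-4-yl, which brings a hydrogen-bond donor, serves at least as well as 3-cyano-4-fluorophenyl. Both a 2.0-fold higher number from compound 3 to compound 4 (0.30 log units; within the scatter) and a 1.5-fold lower number from compound 2 to compound 4 (0.19 log units; within the scatter) lie within the scatter, so the pyrazole cannot be told apart from either 2,6-difluoropyridin-4-yl or 3,5-difluorophenyl. Nothing available here accounts for these numbers.

The compounds shown leave open whether the hydrogen on the pyrazole nitrogen matters, which a 1-methylpyrazol-4-yl group would test. They also leave open how other five-membered rings, such as an imidazole or an isoxazole, would compare at this position.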